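This account rests on a few compounds, and the source may have more. Where it says the series, first, only, none or still open, it means among the compounds named here.

Measured in a functional assay on HEK293 cells (Homo sapiens) for cytotoxicity; a higher number here means that more compound is tolerated, a lower number that less compound is tolerated:
Compound 1 `COc1ccc([C@H]2CC(=O)N(c3cccc(NCc4ccoc4)c3)C2)cc1OC1CCCC1`: > 10000 nM (a limit)
Compound 2 `COc1ccc([C@H]2CC(=O)N(c3cccc(NS(=O)(=O)c4cc(C)ccc4OC)c3)C2)cc1OC1CCCC1`: > 10000 nM (a limit)

In this assay compound 2 gives > 10000 nM, which is a limit of the assay and not a number. Within the data shown here, the series so far consists of the limit of > 10000 nM in this assay, at which 2 of the 2 values shown sit, so compound 2 has no number to work from.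

Compound 3 `COc1ccc([C@H]2CC(=O)N(c3cccc(NS(=O)(=O)c4cccc(Cl)c4)c3)C2)cc1OC1CCCC1` is not yet measured. It carries 3-chlorophenyl in place of 2-methoxy-5-methylphenyl on a sulfonyl sulfur. The sulfonamide nitrogen and the rest of the shared core stay as they are.

Among the measured compounds shown here, one measured step bears on this, at the same nitrogen-linked position: a step that the two limits leave unreadable from compound 1 to compound 2. Its size cannot be read, so it offers no measured effect to carry over. It does show that compound 1 and compound 2, with quite different groups there, both end at the limit. No step beyond the usual scatter is expected in this assay, and no direction is favoured. The expected change is a number no higher from compound 2 to compound 3 (the limit leaves the size open).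

For compound 3 the estimated value is 10000 nM, with an expected range of 5000 nM to 20000 nM.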

Compound 3, half-maximal cytotoxic concentration: > 10000 nM
Compound 3 was reported as a limit; the forecaster's own chance of this, stated with the estimate: 80%; the middle value lies on the limit itself.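

No step can be read among compound 1, compound 2 and compound 3 in this assay. Compound 3 adds another limit and not a number, so the series stands as: the limit of > 10000 nM in this assay, at which 3 of the 3 values shown sit.

The compounds shown leave open how far beyond that limit each compound lies, and whether the group on the sulfonyl sulfur changes the read-out at all.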